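Opening the lactam of a lauroyl-glutamyl NOD1 agonist

The source may report more compounds than this note shows. Statements on the series, on what has been measured and on what is new or still open speak of the compounds shown alone.

Measured compounds:
compound 1, `CCCCCCCCCCCC(=O)N[C@H](CCC(=O)NCCCCCN)C(=O)O`, > 100 nM in a functional assay on HEK293 cells for agonist activity at Nucleotide-binding oligomerization domain-containing protein 1 (Homo sapiens), read by spectrophotometry; a higher number here means that more compound is needed for the effect, a lower number that less compound is needed
compound 2, `CCCCCCCCCCCC(=O)N[C@H](CCC(=O)NC1CCCCNC1=O)C(=O)O`, 1.73 nM in this assay

Compound 2 is the only one of the two with a number in this assay. For compound 1 the value is a limit of the assay, (the limit of > 100 nM in this assay, at which 1 of the 2 values shown sits). Among the measured compounds shown here, the single measured step, an at least 57-fold lower number from compound 1 to compound 2 (1.76 log units; beyond the scatter), is large, going from the open 5-aminopentyl chain to the seven-membered lactam.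

Compound 3, `CCCCCCCCCCCC(=O)N[C@H](CCC(=O)NCCCC[C@@H](N)C(=O)O)C(=O)O`, differs from compound 2 in that (a group of 9 heavy atoms (6 carbon, 1 nitrogen, 2 oxygen; no ring) in place of a group of 8 heavy atoms (6 carbon, 1 nitrogen, 1 oxygen; one seven-membered non-aromatic ring with 1 hetero atom), on an amide-type nitrogen). It returns to an open chain as in compound 1, but the chain now ends in an amino acid with a defined stereocentre rather than a plain amine, so compound 1 gives only a partial guide. A moderate rise in the number is expected, a 2.9-fold higher number from compound 2 to compound 3 (0.46 log units; beyond the scatter), though it may well stay within the scatter. Compound 3 is estimated at 5 nM in this assay, ranging from 1 nM to 40 nM.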

Compound 3, half-maximal effective concentration: 0.37 nM
The estimate for compound 3 lay 14-fold (1.13 log units) above the measured number, and the stated range ends above it.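

Going from the lactam to the open chain gives a 4.7-fold lower number from compound 2 to compound 3 (0.67 log units; beyond the scatter), so the seven-membered ring is not required for a low number in this assay. Among the open chains, carboxy in place of hydrogen on the saturated chain carbon bound to the amine nitrogen gives an at least 270-fold lower number from compound 1 to compound 3 (2.43 log units; beyond the scatter), a large step that shows an open chain can work only with this end group among the compounds shown. Compound 1 stands at a limit of the assay, not at a number: the limit of > 100 nM in this assay, at which 1 of the 3 values shown sits.

The compounds shown leave open what a methyl ester or primary amide in place of the carboxy group, or the opposite configuration at that carbon, would give. They also leave open whether the amine is needed, which a chain ending in a carboxylic acid without that amine would address.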